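Catechol in place of bromophenyl on the shared core

The source may hold more compounds than are shown below. What is called first, only, known or untested is meant among the compounds shown, and "the series" means these compounds.

Compound 3 `COc1ccc(/C=C2\CCC/C(=C\c3cccc(Br)c3)C2=O)cc1OC` gives 4200 nM in a functional assay on SW-620 cells (Homo sapiens) for cytotoxicity, read by MTT assay, with a stated time of 72 h (a higher number here means a weaker inhibitor, a lower number a stronger inhibitor), the lowest of the three numbers to hand. Compound 1 `COc1cccc(/C=C2\CCC/C(=C\c3cccc(Br)c3)C2=O)c1OC` gives 8800 nM and compound 2 `COc1ccc(/C=C2\CCC/C(=C\c3cccc(OC)c3OC)C2=O)cc1` gives 13600 nM; both stand beyond the scatter above compound 3. Compound 4 `COc1ccc(/C=C2\CCC/C(=C\c3ccc(O)c(O)c3)C2=O)cc1OC` is not yet measured. It differs from compound 3 by 3,4-dihydroxyphenyl in place of 3-bromophenyl on a double-bonded chain carbon bound to a double-bonded ring carbon. Going by the values given here, the only measured step that swaps the same group is the exchange of 3-bromophenyl for 4-methoxyphenyl, a 1.5-fold higher number from compound 1 to compound 2 (0.19 log units; within the scatter), which stayed within the scatter. Among the compounds with values here, no measured step puts a 3,4-dihydroxyphenyl in place of a 3-bromophenyl, so the present change has no direct precedent. Within the data shown here, with the one comparable step being flat, no move beyond the scatter is expected for compound 4 in this assay, giving an estimated step of a 1.1-fold higher number from compound 3 to compound 4 (0.03 log units; within the scatter). Compound 4 is therefore estimated at 4500 nM, with a range from 1500 nM to 14000 nM kept wide for the lack of a close precedent.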

Compound 4, half-maximal inhibitory concentration: 10500 nM
Compound 4: middle estimate off by 2.3-fold (0.37 log units), on the low side; the range from low to high includes it.
By their numbers in this assay, from the lowest: compound 3; then compounds 1, 4 and 2 (each within the scatter of the next).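

At the double-bonded chain carbon bound to a double-bonded ring carbon, 3,4-dihydroxyphenyl in place of 3-bromophenyl gives a 2.5-fold higher number from compound 3 to compound 4 (0.40 log units; beyond the scatter) in this assay, so an aryl exchange at this place can move the number beyond the scatter, whereas the earlier exchange gave a 1.5-fold higher number from compound 1 to compound 2 (0.19 log units; within the scatter). The direction favours the 3-bromophenyl of compound 3, which has 0 hydrogen-bond donors, over the 3,4-dihydroxyphenyl of compound 4, which has 2, although one step cannot tie the shift to that count. No measurement on hand accounts for the shift.

The compounds shown leave open whether a single hydroxyl, an amine or a carboxylic acid on this aryl ring would track compound 3 or compound 4. They also leave open whether the step holds with the other dimethoxyphenyl arrangement of compound 1.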